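A few compounds are considered here, and "the series" means these few. Any claim that something is new, unique, unknown or untested is made for them only; others in the source may bear on it.

Compound 1 `Cc1nc(-c2ccccc2F)c(C(=O)N2CCN(c3cc(Cl)cc(Cl)c3)CC2)o1` gives 60.2 nM in a functional assay on HL-60 cells (Homo sapiens) for inhibition, read by MTT assay, with a stated time of 72 h; on this read-out lower numbers stand for stronger inhibition and higher numbers for weaker inhibition; this is the highest of the two numbers measured, the nearest being compound 2 `Cc1nc(-c2ccccc2)c(C(=O)N2CCN(c3cc(Cl)cc(Cl)c3)CC2)o1` with 41.8 nM. The step of a 1.4-fold lower number from compound 1 to compound 2 (0.16 log units; within the scatter), hydrogen in place of fluoro on an aromatic carbon, lies within the scatter. Compound 3 `C=C(C)c1cccc(N2CCN(C(=O)c3oc(C)nc3-c3ccccc3F)CC2)c1` differs from compound 1 by 3-(1-methylethenyl)phenyl in place of 3,5-dichlorophenyl on an amine nitrogen in a ring. Among the compounds with values here, no measured step touches the group on that ring nitrogen, so the direction is open; the only measured step concerns another group and is within the scatter. The expected step is a 2.5-fold higher number from compound 1 to compound 3 (0.40 log units; beyond the scatter), with a wide range. Compound 3 is estimated at 150 nM, between 40 nM and 600 nM.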

Compound 3, half-maximal inhibitory concentration: "not active" (no number reported)
The entry for compound 3 holds no number; no gap can be computed for the estimate.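

Within the data shown here, compound 3 is recorded as "not active" in this assay with no number, so no step from compound 1 to compound 3 can be read. Nothing available bears on this result. The compounds shown leave open how large the effect of 3-(1-methylethenyl)phenyl in place of 3,5-dichlorophenyl is.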